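Acyl cap variation on a shared tripeptide-like core

The source may report more compounds than this note shows. Statements on the series, on what has been measured and on what is new or still open speak of the compounds shown alone.

Measured in an assay on HEK293 cells for inhibition of nuclear factor NF-kappa-B complex (Homo sapiens), read by a luciferase reporter, with stated times of 1 h and 3 h; a higher number here means a weaker inhibitor, a lower number a stronger inhibitor:
compound 1 `CC(C)(C)CNC(=O)C[C@H](NC(=O)C(C)(C)C)C(=O)N[C@@H](CCc1ccccc1)C(=O)NCc1ccccc1`: 62 nM
compound 2 `CC(C)(C)CNC(=O)C[C@H](NC(=O)CN1CCCCC1)C(=O)N[C@@H](CCc1ccccc1)C(=O)NCc1ccccc1`: 62 nM
compound 3 `CC(C)(C)CNC(=O)C[C@H](NC(=O)c1ccc(C(C)(C)C)cc1)C(=O)N[C@@H](CCc1ccccc1)C(=O)NCc1ccccc1`: 32 nM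

Compound 3 has the lowest number of the three, yet it is not separated from the others: the steps of a 1.9-fold lower number from compound 1 to compound 3 (0.29 log units; within the scatter) and a 1.9-fold lower number from compound 2 to compound 3 (0.29 log units; within the scatter) both stay within the scatter, so no order among compounds 1, 2 and 3 can be read from these numbers.

The next compound, compound 4 `Cc1cc(C(=O)N[C@@H](CC(=O)NCC(C)(C)C)C(=O)N[C@@H](CCc2ccccc2)C(=O)NCc2ccccc2)no1`, is the same change cut at the same place: 5-methyl-1,2-oxazol-3-yl in place of 4-(tert-butyl)phenyl on a carbonyl carbon. Every step seen so far alters only this cap on the carbonyl carbon, and none of them moved the number beyond the scatter: no change at the digits printed from compound 1 to compound 2 (within the scatter), a 1.9-fold lower number from compound 1 to compound 3 (0.29 log units; within the scatter), a 1.9-fold lower number from compound 2 to compound 3 (0.29 log units; within the scatter). Three different caps, three numbers that cannot be told apart. On that basis the change to compound 4 is expected to give no step beyond the scatter in this assay either, and the expected step of a 1.6-fold higher number from compound 3 to compound 4 (0.19 log units; within the scatter) is taken as essentially flat. Compound 4 is therefore estimated at 50 nM, with a range from 20 nM to 150 nM.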

Compound 4, half-maximal inhibitory concentration: 9 nM
Compound 4: the middle estimate sits 5.6-fold (0.74 log units) above what was measured, outside the stated range (below it).
By their numbers in this assay, from the lowest: compound 4; then compounds 3, 1 and 2 (each within the scatter of the next).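

In this assay the cap on the carbonyl carbon is not a silent position: 5-methyl-1,2-oxazol-3-yl separates compound 4 from all three earlier caps (a 3.6-fold lower number from compound 3 to compound 4 (0.55 log units; beyond the scatter); a 6.9-fold lower number from compound 2 to compound 4 (0.84 log units; beyond the scatter); a 6.9-fold lower number from compound 1 to compound 4 (0.84 log units; beyond the scatter)), each step beyond the scatter, while compounds 1, 2 and 3 stay unordered among themselves. Against 4-(tert-butyl)phenyl, the entering group differs at once in ring size, hetero atoms, hydrogen-bond acceptors and heavy-atom count, so this single step cannot assign the shift to any one of these features. Nothing at hand explains the shift.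

Open, going by these compounds, is whether the shift survives with an unsubstituted 1,2-oxazol-3-yl cap, or with a plain phenyl or pyridine ring. Also open, on these data alone, is whether a carboxylic acid or an amine on the five-membered ring would keep the number of compound 4.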